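Thiosemicarbazones on a spiro-fused naphthopyranone core: the amine swap

A few compounds are considered here, and "the series" means these few. Any claim that something is new, unique, unknown or untested is made for them only; others in the source may bear on it.

Measured so far in a functional assay on HT-29 cells (Homo sapiens) for antiproliferative activity, read by MTT assay, with a stated time of 96 h; on this read-out lower numbers stand for stronger inhibition and higher numbers for weaker inhibition:
compound 1 `O=C1CC2(CCCCC2)Oc2c1ccc1ccccc21`: 6150 nM
compound 2 `S=C(N/N=C1\CC2(CCCCC2)Oc2c1ccc1ccccc21)N1CCNCC1`: 8340 nM
compound 3 `S=C(N/N=C1\CC2(CCCCC2)Oc2c1ccc1ccccc21)N1CCOCC1`: 9310 nM

Compound 3 gives the highest of the three numbers, yet its nearest neighbour, compound 2, sits only a 1.1-fold higher number from compound 2 to compound 3 (0.05 log units; within the scatter), and the gap to compound 1 is also within the scatter, so no order among the three can be read. Compound 4 `S=C(N/N=C1\CC2(CCCCC2)Oc2c1ccc1ccccc21)NC1CCCCC1` is the next member. The change from compound 3 is cyclohexylamino in place of morpholin-4-yl on a thiocarbonyl carbon. For the measured compounds named here, the one step that bears on it is the earlier swap on the same thiocarbonyl carbon, a 1.1-fold higher number from compound 2 to compound 3 (0.05 log units; within the scatter), which moved nothing beyond the scatter. A step of a 1.2-fold lower number from compound 3 to compound 4 (0.07 log units; within the scatter) is therefore expected, with no direction beyond the scatter. Compound 4 is estimated at 8000 nM, between 4000 nM and 16000 nM in this assay.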

Compound 4, half-maximal inhibitory concentration: 7440 nM
The estimate for compound 4 lay 1.1-fold (0.03 log units) above the measured number; the range from low to high includes it.
By their numbers in this assay, from the lowest: compounds 1, 4, 2 and 3 (each within the scatter of the next).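

Putting cyclohexylamino, a ring of carbon only carrying a hydrogen-bond donor, in place of morpholin-4-yl on the thiocarbonyl carbon gives a 1.3-fold lower number from compound 3 to compound 4 (0.10 log units; within the scatter), and putting it in place of piperazin-1-yl gives a 1.1-fold lower number from compound 2 to compound 4 (0.05 log units; within the scatter). Neither step lies beyond the scatter, so even the loss of the ring oxygen of morpholin-4-yl and the gain of that donor leave the number unresolved from those of the two earlier amines. Nothing available explains this flatness. From the compounds shown here alone, whether a phenylamino group or a longer chain such as n-butylamino at this carbon would move the number beyond the scatter remains open.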